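Swapping a Phenethyl Tail for a Dimethylaminophenoxy Group

A few compounds are considered here, and "the series" means these few. Any claim that something is new, unique, unknown or untested is made for them only; others in the source may bear on it.

Compound 1 `CC(C)Cc1ccc2c(NCCCNCc3ccco3)ccnc2c1` and compound 2 `c1ccc(CCc2ccc3c(NCCCNCc4ccco4)ccnc3c2)cc1` share one core and differ at a single spot, where a benzyl group replaces an isopropyl group on a saturated chain carbon bound to an aromatic carbon. In an ADME assay on HepG2 cells (Homo sapiens) for cytotoxicity, read by luminescence, CellTiter-Glo and ATP content, with a stated time of 72 h (on this read-out higher numbers stand for an effect only at larger amounts of compound and lower numbers for an effect already at smaller amounts), compound 1 gives 16000 nM, and compound 2 gives 16000 nM. Going by the values given here, the single measured step, no change at the digits printed from compound 1 to compound 2 (within the scatter), shows that exchanging one carbon-only group for another at this position left the read-out where it was. On the numbers shown, compound 2 therefore stands level with compound 1.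

Compound 3 `CN(C)c1cccc(Oc2ccc3c(NCCCNCc4ccco4)ccnc3c2)c1` is the next compound to be measured, and it arises from compound 2 by 3-(dimethylamino)phenoxy in place of phenethyl on an aromatic carbon. The earlier step, which bears on this one, concerned the same position and was flat within the scatter. Among the compounds with values here, the entering group, however, brings an oxygen and a nitrogen and two hydrogen-bond acceptors, for which no measured step exists. What is expected is no change at the digits printed from compound 2 to compound 3 (within the scatter), a shift no larger than the usual scatter. Compound 3 is accordingly estimated to give 16000 nM, in a range from 6000 nM to 40000 nM.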

Compound 3, half-maximal effective concentration: 16000 nM
Compound 3: middle estimate and measured number agree at the digits printed; low and high end bracket the measured number.
By their numbers in this assay, from the lowest: compounds 1, 2 and 3 (each within the scatter of the next).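

In this assay, replacing phenethyl with 3-(dimethylamino)phenoxy gives no change at the digits printed from compound 2 to compound 3 (within the scatter), and the wider comparison, with 3-(dimethylamino)phenoxy in place of isobutyl, gives no change at the digits printed from compound 1 to compound 3 (within the scatter). The earlier step involved only groups built from carbon and hydrogen, whereas the group entering here brings a nitrogen, an oxygen and hydrogen-bond acceptors, so the flat result at this aromatic carbon now extends to a group with atoms other than carbon and hydrogen. Nothing available explains why the read-out stays in place across these three groups.

On these data alone, it remains open whether the same flat result would hold for a carboxylic acid, a primary amine or a longer alkyl chain on this aromatic carbon, since all three groups seen so far are either branched alkyl or end in a six-membered aromatic ring of carbon only. The three compounds also share the rest of their structure, so they give no information on how a change elsewhere on the shared core would affect this assay.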